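The compounds below may be only part of what the source reports. "The series", "measured", "known", "first", "only" and "open" are said of these compounds alone.

The measured compounds in an ADME assay on THP-1 cells (Homo sapiens) for cytotoxicity; on this read-out higher numbers stand for lower toxicity in this test and lower numbers for higher toxicity in this test:
compound 1 `Cc1ccsc1[C@@H]1C[C@H](O)Cc2cc(Cl)ccc2N1` gives 181000 nM;
compound 2 `Cc1ccc([C@@H]2C[C@H](O)Cc3cc(F)ccc3N2)s1` gives 312000 nM;
compound 3 `Cc1ccsc1[C@@H]1C[C@H](O)Cc2cc(F)ccc2N1` gives 1810000 nM.

Compound 3 stands highest of the three numbers in this assay. Its nearest neighbour is compound 2, and the step of a 5.8-fold higher number from compound 2 to compound 3 (0.76 log units; beyond the scatter) is beyond the scatter; the furthest is compound 1, and the step of a 10-fold higher number from compound 1 to compound 3 (1.00 log units; beyond the scatter) is likewise beyond the scatter. Compound 4 `O[C@@H]1Cc2cc(F)ccc2N[C@H](c2ccoc2)C1` has not yet been measured. It differs from compound 3 in one place: furan-3-yl in place of 3-methylthiophen-2-yl on a saturated ring carbon. Of the measured steps, only a 5.8-fold higher number from compound 2 to compound 3 (0.76 log units; beyond the scatter) concerns the group on this saturated ring carbon, and that step was modest. The present exchange goes further, replacing one heteroaromatic ring by a different one and dropping the methyl, so the data give no firm direction. Compound 3 already sits at the top of the three numbers, and a modest fall back toward the others is expected, with an estimated step of a 2.0-fold lower number from compound 3 to compound 4 (0.30 log units; within the scatter). For compound 4 the expected value in this assay is 900000 nM, with a range from 200000 nM to 4000000 nM.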

Compound 4, half-maximal cytotoxic concentration: 689000 nM
Compound 4: middle estimate off by 1.3-fold (0.12 log units), on the high side, and the stated range covers the measured number.
By their numbers in this assay, from the lowest: compounds 1 and 2 (each within the scatter of the next); then compound 4; then compound 3.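

On the saturated ring carbon next to the ring nitrogen, a furan-3-yl group gives a number that lies between those of the two methylthiophene isomers in this assay. Exchanging 3-methylthiophen-2-yl for furan-3-yl gives a 2.6-fold lower number from compound 3 to compound 4 (0.42 log units; beyond the scatter), whereas exchanging 5-methylthiophen-2-yl for it gives a 2.2-fold higher number from compound 2 to compound 4 (0.34 log units; beyond the scatter), so the same incoming ring moves the number down or up depending on the group it replaces, and a methylthiophene is not needed to reach this range. Nothing available explains these shifts.

From the compounds shown here alone, each exchange changes the ring and removes the methyl together, so the part played by each change remains open. Going by these compounds, it is also open whether the fluoro-to-chloro step carries over to furan-3-yl, and how a phenyl ring or an aminomethyl group would read at this carbon.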